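A few compounds are considered here, and "the series" means these few. Any claim that something is new, unique, unknown or untested is made for them only; others in the source may bear on it.

Series notes. The shared core of compound 1 `CC(C)[C@H](C(=O)Nc1ccccc1)c1ccc(Cl)cc1` carries an amide nitrogen that bears a phenyl; in a functional assay on CHO cells for agonist activity at Free fatty acid receptor 2 (Homo sapiens), read by cAMP accumulation (a higher number here means a weaker inhibitor, a lower number a stronger inhibitor), compound 1 gives only a limit, > 100000 nM, and not a number. Compound 2 `CC(C)[C@H](C(=O)Nc1ncc[nH]1)c1ccc(Cl)cc1` carries a 1H-imidazol-2-yl in its place and in this assay compound 2 gives 20000 nM. Compound 3 `CC(C)[C@H](C(=O)Nc1ccon1)c1ccc(Cl)cc1` carries a 1,2-oxazol-3-yl and in this assay compound 3 gives 36000 nM. The step of an at least 5.0-fold lower number from compound 1 to compound 2 (0.69 log units; beyond the scatter) and the step of an at least 2.7-fold lower number from compound 1 to compound 3 (0.44 log units; beyond the scatter) both point the same way, while the step of a 1.8-fold higher number from compound 2 to compound 3 (0.26 log units; within the scatter) lies within the scatter. Compound 3 therefore has the higher of the two numbers, with compound 2 close to it and compound 1 at a limit (the limit of > 100000 nM in this assay, at which 1 of the 3 values shown sits).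

Compound 4 `CC(C)[C@H](C(=O)Nc1ncc(C#N)s1)c1ccc(Cl)cc1` is not yet measured. It differs from compound 3 by 5-cyano-1,3-thiazol-2-yl in place of 1,2-oxazol-3-yl on an amide-type nitrogen. Both measured steps from the phenyl amide of compound 1 to a five-membered heteroaryl gave an at least modest move, and the two heteroaryls sit within the scatter of each other; on that basis the step of a 2.4-fold lower number from compound 3 to compound 4 (0.38 log units; beyond the scatter) is expected to be small, within or just beyond the scatter, in the lower direction. Compound 4 is estimated at 15000 nM, with a range of 3000 nM to 60000 nM.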

Compound 4, half-maximal inhibitory concentration: 2000 nM
The estimate for compound 4 lay 7.5-fold (0.88 log units) above the measured number, outside the stated range (below it).
By their numbers in this assay, from the lowest: compound 4; then compounds 2 and 3 (each within the scatter of the next). At a limit, above all of these: compound 1.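

Among these compounds, at this place on the amide-type nitrogen, compounds 2 and 3 lay within the scatter of each other, so the earlier compounds showed only that a five-membered heteroaryl differs from phenyl; in this assay, the choice of heteroaryl now matters too: an 18-fold lower number from compound 3 to compound 4 (1.26 log units; beyond the scatter), and a 10-fold lower number from compound 2 to compound 4 (1.00 log units; beyond the scatter). Compound 4 has the lowest number of the series, with its steps to all the others beyond the scatter. Compound 1 stands at a limit and not a number, so an at least 50-fold lower number from compound 1 to compound 4 (1.69 log units; beyond the scatter) is a bound only: the limit of > 100000 nM in this assay, at which 1 of the 4 values shown sits.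

The compounds shown leave open whether the step belongs to the 1,3-thiazol-2-yl ring or to the nitrile, as both enter together. A 1,3-thiazol-2-yl bearing no substituent, or bearing a methyl or a carboxylic acid in place of the nitrile, would separate the two.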